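Swapping the Aryl on the Ring Nitrogen of Compound 1

This account rests on a few compounds, and the source may have more. Where it says the series, first, only, none or still open, it means among the compounds named here.

Measured so far in a functional assay on PC-12 cells (Rattus norvegicus) for cytotoxicity, read by MTT assay, with stated times of 2 h and 24 h, tested at 5 uM; a higher number here means a stronger effect of the compound at the concentration tested, a lower number a weaker effect:
Compound 1 `CC(C)c1ccc(-n2nc(-c3ccc(C(F)(F)F)cc3O)nc2-c2ccccc2O)cc1` gives 100%.
Compound 2 `Oc1cc(C(F)(F)F)ccc1-c1nc(-c2ccccc2O)n(-c2ccc(F)cc2F)n1` gives 83.5%.

Compound 1 stands highest of the two numbers in this assay; its nearest neighbour is compound 2, and the step of a number 16.5 percentage points lower from compound 1 to compound 2 (beyond the scatter) lies beyond the scatter, a modest fall. The unmeasured compound 3 `Oc1cc(C(F)(F)F)ccc1-c1nc(-c2ccccc2O)n(-c2cc(F)cc(F)c2)n1` differs from compound 1 in one place: 3,5-difluorophenyl in place of 4-isopropylphenyl on an aromatic nitrogen. Among the compounds with values here, the only measured step that bears on this change is a number 16.5 percentage points lower from compound 1 to compound 2 (beyond the scatter), where a difluorophenyl likewise replaced the 4-isopropylphenyl on the aromatic nitrogen; that step carried the 2,4-difluorophenyl, whereas compound 3 carries the 3,5-difluorophenyl, and no measured pair separates the two. The expectation for compound 3 in this assay is therefore a step of about the size and direction seen in compound 2, a modest fall below compound 1 rather than none beyond the scatter, with added uncertainty from the untested fluorine pattern. Compound 3 is estimated at 82%, in the range 65% to 100%, which means an expected step of a number 18 percentage points lower from compound 1 to compound 3 (beyond the scatter).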

Compound 3, a percentage reported as activity, at one concentration (the size of the read-out at that concentration, not a potency): 100%
Beside the measured number, compound 3's estimate is 18 percentage points below it; measured number inside the range.
By their numbers in this assay, from the lowest: compound 2; then compounds 1 and 3 (each within the scatter of the next).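

In this assay, the 3,5-difluorophenyl in place of 4-isopropylphenyl on the aromatic nitrogen gives no change at the digits printed from compound 1 to compound 3 (within the scatter), so among these compounds exchanging the 4-isopropylphenyl for a difluorophenyl does not in itself lower the read-out. The two difluorophenyl groups are not interchangeable here: exchanging one for the other gives a number 16.5 percentage points higher from compound 2 to compound 3 (beyond the scatter), which ties the earlier fall to the 2,4-difluorophenyl of compound 2 and not to difluorophenyl groups as a whole. This position on the aromatic nitrogen therefore accepts both the 4-isopropylphenyl and the 3,5-difluorophenyl without a change beyond the scatter, while the read-out still responds to how the fluorines are arranged on the ring.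

No evidence at hand gives a reason for the gap between the two difluorophenyl groups. As far as these compounds go, it remains open whether a phenyl with a single fluorine, a phenyl bearing an amine or a carboxylic acid, or a longer chain on this aromatic nitrogen would stay level with compound 1 or fall toward compound 2, and a read-out at one concentration cannot say how compound 1 and compound 3 compare in potency.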